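This account rests on a few compounds, and the source may have more. Where it says the series, first, only, none or still open, it means among the compounds named here.

Measured compounds:
compound 1 `Cn1cnc2c(Nc3ccccc3)ncnc21`: 0%
compound 2 `Cn1cnc2c(Nc3ccc(F)cc3)ncnc21`: 8%
compound 3 `Cn1cnc2c(Sc3ccccc3)ncnc21`: 8%

In an assay on isolated protein for inhibition of Ca2+/calmodulin-dependent protein kinase II (CaM kinase II) (Rattus norvegicus), tested at 30 uM (a higher number here means more inhibition at the concentration tested (going by the name of the read-out), a lower number less inhibition), compound 1 gives 0%. Compound 2 gives 8% and compound 3 gives 8% in this assay. Compound 2 differs from compound 1 by one change, (fluoro in place of hydrogen on an aromatic carbon), and that change made a step of a number 8 percentage points higher from compound 1 to compound 2 (within the scatter). Compound 3 and compound 2 show the same number at the digits given, and compound 3 stands within the scatter of compound 1 as well; all three numbers sit low and close together. How the core of compound 3 differs from the core of compound 1 is not broken down here.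

Compound 4 `Cn1cnc2c(Sc3ccc(F)cc3)ncnc21` is not yet measured. It carries the same change on the core of compound 3: fluoro in place of hydrogen on an aromatic carbon. The step from compound 3 to compound 4 in this assay is expected to be a number 4 percentage points higher from compound 3 to compound 4 (within the scatter), a small one, because the same change gave a number 8 percentage points higher from compound 1 to compound 2 (within the scatter). Compound 4 is therefore expected to read about 12%, with the range 0% to 28% covering the likely outcome.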

Compound 4, a percentage reported as inhibition, at one concentration (the size of the read-out at that concentration, not a potency): 5%
For compound 4 the middle estimate is 7 percentage points above the measured one; the range from low to high includes it.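

On the core of compound 3, fluoro in place of hydrogen on an aromatic carbon, para to a large group, gives a number 3 percentage points lower from compound 3 to compound 4 (within the scatter) in this assay. Set beside the same change on the core of compound 1, the two steps do not separate: the same change on two cores in this assay, a number 8 percentage points higher (within the scatter) from compound 1 to compound 2 and a number 3 percentage points lower (within the scatter) from compound 3 to compound 4, 11 percentage points apart, within the scatter of two such steps. Among the compounds shown here, this shows that neither core gives a step beyond the scatter for this change, and that the two cores cannot be told apart in how they carry it; it does not show that the change transfers with a fixed size or direction, or that it would do nothing on other cores, and with only two pairs, all reading low, the comparison is a weak test.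

Open, going by these compounds, is whether a different group on the same aromatic ring, such as a carboxylic acid or an amine, would move the reading beyond the scatter on either core. Also open, on these data alone, is whether a longer chain in place of the methyl on the shared core would do so.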